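From 3-chlorophenyl to 3,4-dimethoxyphenyl in growth inhibition

The compounds below may be only part of what the source reports. "The series", "measured", "known", "first", "only" and "open" are said of these compounds alone.

Values in a functional assay on DWD cells (Homo sapiens) for inhibition, read by sulforhodamine B assay (on this read-out lower numbers stand for stronger inhibition of growth and higher numbers for weaker inhibition of growth), for the measured compounds
Compound 1 `COc1ccc(-c2ccc(-c3ccc(-c4nc5cc(C)ccc5[nH]4)cc3)cc2)cc1OC` gives 1720 nM
Compound 2 `Oc1ccc(-c2ccc(-c3ccc(-c4nc5ccccc5[nH]4)cc3)cc2)cc1` gives 46300 nM
Compound 3 `Clc1cccc(-c2ccc(-c3ccc(-c4nc5ccccc5[nH]4)cc3)cc2)c1` gives 100000 nM

Compound 3 stands at the top of these numbers, with 100000 nM as the highest of the three. Compound 4 `COc1ccc(-c2ccc(-c3ccc(-c4nc5ccccc5[nH]4)cc3)cc2)cc1OC` differs from it by one change, 3,4-dimethoxyphenyl in place of 3-chlorophenyl on an aromatic carbon, para to a large group, counted as 3,4-dimethoxyphenyl in place of 3-chlorophenyl on an aromatic carbon in full. For the measured compounds named here, the one measured step at this place shows a 2.2-fold higher number from compound 2 to compound 3 (0.33 log units; beyond the scatter) but involves a different incoming group, so it offers little guidance on size. Compound 1 carries the same 3,4-dimethoxyphenyl group together with a methyl group on the core, and compound 1 gives 1720 nM which lies well under the number of compound 3. Going by the values given here, no measured pair shows what that methyl group contributes alone. A large step toward a lower number is therefore expected in this assay for this change. The expected step is a 33-fold lower number from compound 3 to compound 4 (1.52 log units; beyond the scatter) in size. Compound 4 is estimated at 3000 nM with an expected range from 800 nM to 12000 nM in this read-out.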

Compound 4, concentration for 50% growth inhibition: 42100 nM
The estimate for compound 4 lay 14-fold (1.15 log units) below the measured number; the whole stated range lies below it.
By their numbers in this assay, from the lowest: compound 1; then compounds 4 and 2 (each within the scatter of the next); then compound 3.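

In this assay, the 3,4-dimethoxyphenyl group in place of 3-chlorophenyl gives only a 2.4-fold lower number from compound 3 to compound 4 (0.38 log units; beyond the scatter) at this position, so the change alone has a modest effect. Set against the 4-hydroxyphenyl group, the same group gives a 1.1-fold lower number from compound 2 to compound 4 (0.04 log units; within the scatter) and cannot be told apart from it on this read-out. For the compounds shown here, the large difference instead follows the single change on the core, hydrogen in place of methyl, with a 24-fold higher number from compound 1 to compound 4 (1.39 log units; beyond the scatter) as the first measured pair to isolate the methyl group.

No supporting data offer a reason for any of these differences. From the compounds shown here alone, it remains open whether the methyl group gives a similar step alongside 3-chlorophenyl or 4-hydroxyphenyl, and whether an ethyl group or a chlorine atom at that place on the core would match it.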